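From Indazolyl to Vinylphenyl: An Expected Shift in HeLa Inhibition

A few compounds are considered here, and "the series" means these few. Any claim that something is new, unique, unknown or untested is made for them only; others in the source may bear on it.

Measured compounds:
compound 1 `COc1ccc(-c2cc3nccc(-c4cc(OC)c(OC)c(OC)c4)n3n2)cc1[N+](=O)[O-]` — > 10000 nM
compound 2 `COc1cc(-c2ccnc3cc(-c4ccc5ccn(C)c5c4)nn23)cc(OC)c1OC` — 187 nM
compound 3 `COc1cc(-c2ccnc3cc(-c4ccc5cnn(C)c5c4)nn23)cc(OC)c1OC` — 97 nM

Within the data shown here, in a functional assay on HeLa cells (Homo sapiens) for inhibition, read by CCK-8 assay, with a stated time of 48 h (on this read-out higher numbers stand for weaker inhibition and lower numbers for stronger inhibition), compound 3 gives 97 nM, one of only two numbers in hand; compound 2 sits within the scatter of it, as the step of a 1.9-fold lower number from compound 2 to compound 3 (0.29 log units; within the scatter) shows. The result for compound 1 is a limit of the assay, not a number (the limit of > 10000 nM in this assay, at which 1 of the 3 values shown sits). Compound 4 `C=Cc1ccc(-c2cc3nccc(-c4cc(OC)c(OC)c(OC)c4)n3n2)cc1` differs from compound 3 by 4-vinylphenyl in place of 1-methyl-1H-indazol-6-yl on an aromatic carbon. Among the measured compounds shown here, the single measured step exchanges one fused two-ring group for another and stays within the scatter, so it says little about putting a single ring carrying a vinyl group in its place. For the measured compounds named here, with no step of this kind measured, a modest weakening is expected, a 3.1-fold higher number from compound 3 to compound 4 (0.49 log units; beyond the scatter). Compound 4 is estimated at 300 nM, within a range from 80 nM to 1500 nM.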

Compound 4, half-maximal inhibitory concentration: 882 nM
Estimate against measurement, compound 4: 2.9-fold (0.47 log units) below, and the stated range covers the measured number.
By their numbers in this assay, from the lowest: compounds 3 and 2 (each within the scatter of the next); then compound 4. At a limit, above all of these: compound 1.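

Replacing the fused two-ring group at this position with 4-vinylphenyl weakens inhibition beyond the scatter, giving a 9.1-fold higher number from compound 3 to compound 4 (0.96 log units; beyond the scatter) and a 4.7-fold higher number from compound 2 to compound 4 (0.67 log units; beyond the scatter) as modest steps. Whereas exchanging one fused two-ring group for another left the numbers within the scatter, this position does respond to the change to a single ring carrying a vinyl group. Nothing shown here accounts for this shift.

From the compounds shown here alone, it remains open whether the step follows from losing the second ring or from the vinyl group itself. An amine or a carboxylic acid in place of the vinyl group also remains untested in the compounds shown.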